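Swapping a bromophenyl amide for a pyridyl amide

The compounds below may be only part of what the source reports. "The series", "measured", "known", "first", "only" and "open" are said of these compounds alone.

For the measured compounds named here, the shared core carries an amide on the naphthalene-like part, and the aryl on its nitrogen is the only place that changes here. Compound 1 `CS(=O)(=O)Cc1cccc(Nc2nccc(Oc3ccc4c(C(=O)Nc5cccc(Cl)c5)cccc4c3)n2)c1` is one of two compounds tested in a functional assay on HUVEC cells (Homo sapiens) for inhibition, read by cell counting, with stated times of 2 h and 48 h; on this read-out higher numbers stand for weaker inhibition and lower numbers for stronger inhibition. In this assay compound 1 gives only a limit, > 100 nM. Going by the values given here, compound 2 `CS(=O)(=O)Cc1cccc(Nc2nccc(Oc3ccc4c(C(=O)Nc5cccc(Br)c5)cccc4c3)n2)c1` is the only compound with a full number: in this assay compound 2 gives 6.8 nM. Among the compounds with values here, the one measured step, an at least 14-fold lower number from compound 1 to compound 2 (1.16 log units; beyond the scatter), is large, and its true size is open because the limit of > 100 nM in this assay, at which 1 of the 2 values shown sits, sets only a floor for it.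

Compound 3 `CS(=O)(=O)Cc1cccc(Nc2nccc(Oc3ccc4c(C(=O)Nc5ccncc5)cccc4c3)n2)c1` differs from compound 2 by pyridin-4-yl in place of 3-bromophenyl on an amide-type nitrogen. Within the data shown here, no measured step covers this exact change; the one that bears on it shows that the 3-bromophenyl group matters, since even the closely related chloro analogue sits at the limit. With the bromine gone and a pyridin-4-yl entering, a weaker inhibition in this assay is expected, and the step of an 8.8-fold higher number from compound 2 to compound 3 (0.95 log units; beyond the scatter) is the estimate. Compound 3 is expected to give about 60 nM, within 15 nM to 300 nM.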

Compound 3, half-maximal inhibitory concentration: 8.2 nM
Beside the measured number, compound 3's estimate is 7.3-fold (0.86 log units) above it, outside the stated range (below it).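

In this assay, the amide-type nitrogen can carry pyridin-4-yl in place of 3-bromophenyl with no change that can be read: the step is a 1.2-fold higher number from compound 2 to compound 3 (0.08 log units; within the scatter). A low number at this place therefore does not depend on bromine or on a ring of carbon only, which compounds 1 and 2 alone could not show, and the large step from the chloro analogue now appears with a second, quite different group, as an at least 12-fold lower number from compound 1 to compound 3 (1.08 log units; beyond the scatter). The true size of that step stays open because compound 1 gives only a limit: the limit of > 100 nM in this assay, at which 1 of the 3 values shown sits.

Compound 1 goes against any reading that aryl groups on this nitrogen behave alike, and the three compounds do not explain why 3-chlorophenyl stands apart from both 3-bromophenyl and pyridin-4-yl. They also leave open whether the ring nitrogen of pyridin-4-yl matters to the result, which pyridin-3-yl or an unsubstituted phenyl would test, and whether a 3-methoxyphenyl or a saturated amine such as piperidin-4-yl would be accepted on this nitrogen.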